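The compounds below may be only part of what the source reports. "The series", "measured", "known", "first", "only" and "open" are said of these compounds alone.

Two measured compounds open this account. Compound 1 `O=C(/C(=C\c1c(O)cc(O)cc1O)Sc1ccccc1Br)c1ccc(Br)cc1` gives in a functional assay on DU-145 cells (Homo sapiens) for inhibition, read by trypan blue exclusion, with a stated time of 96 h (a lower number here means a stronger inhibitor of growth, a higher number a weaker inhibitor of growth), only a limit of the assay, > 100000 nM. Compound 2 `COc1ccc(C(=O)/C(=C\c2ccc(Br)cc2)Sc2ccc(F)cc2)cc1` likewise returns a limit in this assay, > 100000 nM. Where compound 2 stands is therefore only a boundary: the number shown for it is the limit, (the limit of > 100000 nM in this assay, at which 2 of the 2 values shown sit), and no finer reading exists for it. From compound 2 to compound 3 `COc1ccc(C(=O)/C(=C\c2ccc(Cl)cc2)Sc2ccc(F)cc2)cc1` the change is small: chloro in place of bromo on an aromatic carbon. Chloro in place of bromo on an aromatic carbon, para to a large group, is the whole of the change. No step between measured compounds is available, so nothing shows how far such a change moves this assay; on what is shown, no step beyond the usual scatter is expected in either direction, and the step that the limit leaves unreadable from compound 2 to compound 3 is estimated on that basis. Compound 3 is therefore expected to give 150000 nM, within a range from 50000 nM to 500000 nM, and most probably again only a limit.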

Compound 3, concentration for 50% growth inhibition: > 100000 nM
Compound 3: a limit, no number; the forecaster's own chance of this, stated with the estimate: 75%; the middle value lies beyond the limit too.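

In this assay, among these compounds, compound 3 gives > 100000 nM, a limit and not a number, so no step from compound 2 to compound 3 can be read. The compounds shown leave open whether any change to the shared core gives a measurable concentration for growth inhibition: the limit of > 100000 nM in this assay, at which 3 of the 3 values shown sit.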